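Cyclopentyl for methoxyphenyl on the vinyl chain

The source may hold more compounds than are shown below. What is called first, only, known or untested is meant among the compounds shown, and "the series" means these compounds.

Measured compounds in a functional assay on HL-60 cells (Homo sapiens) for cytotoxicity, read by WST assay, with a stated time of 48 h; a higher number here means a weaker inhibitor, a lower number a stronger inhibitor:
compound 1 `COc1ccc(/C=C/C[C@@H]2C[C@@H]([C@@H](O)c3ccc(OC)c(OC)c3)CO[C@H]2c2ccc(OC)c(OC)c2)cc1OC`: 26000 nM
compound 2 `COc1cccc(/C=C/C[C@H]2C[C@@H]([C@@H](O)c3ccccc3)CO[C@@H]2c2ccccc2)c1`: 9620 nM
compound 3 `O[C@@H](c1ccccc1)[C@H]1CO[C@H](c2ccccc2)[C@@H](C/C=C/c2ccccc2)C1`: 7040 nM

Compound 2 stands second highest of the three numbers in this assay; its nearest neighbour is compound 3, with a 1.4-fold lower number from compound 2 to compound 3 (0.14 log units; within the scatter), while compound 1 lies furthest away, higher and beyond the scatter. Compound 4 `O[C@@H](c1ccccc1)[C@H]1CO[C@H](c2ccccc2)[C@@H](C/C=C/C2CCCC2)C1` differs from compound 2 in one place: cyclopentyl in place of 3-methoxyphenyl on a double-bonded chain carbon bound to a double-bonded chain carbon. Among the measured compounds shown here, the one measured step, a 1.4-fold lower number from compound 2 to compound 3 (0.14 log units; within the scatter), concerns only hydrogen in place of methoxy at the same chain end and stays within the scatter; no measured pair exchanges the aromatic ring for a non-aromatic one, so the change is untested here. For this assay no step beyond the scatter is therefore expected, with wide uncertainty. Compound 4 is estimated at 10000 nM, within 3500 nM to 28000 nM. The expected step is a 1.0-fold higher number from compound 2 to compound 4 (0.02 log units; within the scatter).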

Compound 4, half-maximal inhibitory concentration: 9060 nM
Estimate against measurement, compound 4: 1.1-fold (0.04 log units) above; low and high end bracket the measured number.
By their numbers in this assay, from the lowest: compounds 3, 4 and 2 (each within the scatter of the next); then compound 1.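

In this assay, cyclopentyl on a double-bonded chain carbon bound to a double-bonded chain carbon gives a 1.1-fold lower number from compound 2 to compound 4 (0.03 log units; within the scatter) in place of 3-methoxyphenyl and a 1.3-fold higher number from compound 3 to compound 4 (0.11 log units; within the scatter) in place of phenyl, both within the scatter. An aromatic ring at this place is therefore not needed for a number in this range, which compounds 2 and 3, both aromatic there, could not show. Nothing available explains this result.

Open, on these data alone, is whether an amine, a carboxylic acid or a longer chain at this place would also leave the number unchanged. Also open, as far as these compounds go, is whether cyclopentyl would behave the same way on the core of compound 1.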